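Fluoro on the aryl of the acylguanidine: expected maximal response

The compounds below may be only part of what the source reports. "The series", "measured", "known", "first", "only" and "open" are said of these compounds alone.

Two guanidine compounds sharing the imidazolylpropyl chain have been run in a functional assay on cardiac atrium for agonist activity at histamine H2 receptor (Cavia porcellus); on this read-out lower numbers stand for smaller maximal responses and higher numbers for larger maximal responses. Compound 1 `N=C(NCCCc1c[nH]cn1)NCCC(c1ccc(F)cc1)c1ccccn1` gives 100% in this assay. Compound 2 `N=C(NCCCc1c[nH]cn1)NC(=O)CC(c1ccccc1)c1ccccc1` gives 85% in this assay, which places compound 2 at the lower of the two numbers, with compound 1 the nearer neighbour at a value that lies beyond the scatter above it. Among the compounds with values here, no pair differing in one place has yet been measured, so no step size from a single change is known.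

Compound 3 `N=C(NCCCc1c[nH]cn1)NC(=O)CC(c1ccccc1)c1ccc(F)cc1` is the next member. It differs from compound 2 by fluoro in place of hydrogen on an aromatic carbon, the change sitting on an aromatic carbon of a six-membered aromatic ring of carbon only. Within the data shown here, with no measured single-point step to lean on, the expected step from compound 2 to compound 3 in this assay is small, a number 3 percentage points higher from compound 2 to compound 3 (within the scatter), not clearly beyond the scatter in either direction. Compound 3 is therefore estimated to reach 88% in this assay, within a range from 72% to 102%.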

Compound 3, largest response reached (Emax), in percent of the reference or control that the assay uses: 95%
For compound 3 the middle estimate is 7 percentage points below the measured one, within the range that was stated.
By their numbers in this assay, from the lowest: compounds 2, 3 and 1 (each within the scatter of the next, the first and the last beyond it).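

Within the data shown here, compound 2 and compound 3 are the first pair that differs in one place, so the size of a single change can now be read: in this assay, going from phenyl to 4-fluorophenyl gives a number 10 percentage points higher from compound 2 to compound 3 (within the scatter). This step stays inside the scatter, so fluoro in place of hydrogen at this place, para to a large group, gives no maximal response that can be told apart from that of compound 2. Nothing on hand gives a reason for the size of this step.

Open, from the compounds shown here alone, is whether chloro, methyl or methoxy at the same place would give a step beyond the scatter. Also open, going by these compounds, is how a longer chain in place of the imidazolylpropyl chain would read in this assay.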